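The source may hold more compounds than are shown below. What is called first, only, known or untested is meant among the compounds shown, and "the series" means these compounds.

Notes on the series, step from compound 1 to compound 3.

Compound 1 `Cc1c(C(=O)N/N=C\c2ccccc2F)oc2cccc(O)c12` is the reference point. In a functional assay on PC-3 cells (Homo sapiens) for inhibition (a higher number here means a weaker inhibitor, a lower number a stronger inhibitor), compound 1 gives >= 40000 nM, which is a limit of the assay and not a measured number. Within the data shown here, compound 2 `Cc1c(C(=O)N/N=C\c2c(O)cccc2Cl)oc2cccc(O)c12` is the only other compound with a value so far; in this assay compound 2 gives 18700 nM. Among the measured compounds shown here, the one measured step, an at least 2.1-fold lower number from compound 1 to compound 2 (0.33 log units; beyond the scatter), replaces 2-fluorophenyl with 2-chloro-6-hydroxyphenyl on a carbon with a double bond to nitrogen, and its size is known only as a bound, since compound 1 sits at the limit of >= 40000 nM in this assay, at which 1 of the 2 values shown sits.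

Compound 3 `Cc1c(C(=O)N/N=C\c2cc(Cl)ccc2O)oc2cccc(O)c12` has not yet been measured. Its change from compound 1 is 5-chloro-2-hydroxyphenyl in place of 2-fluorophenyl on a carbon with a double bond to nitrogen. This resembles the step to compound 2 in that a hydroxyl enters the ring beside a chlorine, though the chlorine is placed differently. The expectation for compound 3 is therefore a step in the same direction, of similar or smaller size, and compound 3 is expected to show an at least 1.6-fold lower number from compound 1 to compound 3 (0.20 log units; that floor lies within the scatter) in this assay. Compound 3 is estimated at 25000 nM, within 10000 nM to 60000 nM, with a real chance that only a limit is reported.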

Compound 3, half-maximal inhibitory concentration: 3120 nM
Beside the measured number, compound 3's estimate is 8.0-fold (0.90 log units) above it; measured number below the stated range.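

In this assay, 5-chloro-2-hydroxyphenyl in place of 2-fluorophenyl on the carbon with a double bond to nitrogen gives an at least 12-fold lower number from compound 1 to compound 3 (1.10 log units; beyond the scatter), a large step that can be read only as a bound: the limit of >= 40000 nM in this assay, at which 1 of the 3 values shown sits.

Among these compounds, what the earlier compounds did not show is that the arrangement of the two new substituents on this ring counts: 5-chloro-2-hydroxyphenyl in place of 2-chloro-6-hydroxyphenyl gives a 6.0-fold lower number from compound 2 to compound 3 (0.78 log units; beyond the scatter). The mere presence of a chlorine and a hydroxyl on this ring therefore does not set the number in this pair, and the pattern rests on compound 2 and compound 3 alone.

From the compounds shown here alone, how much of the step from the fluorinated ring belongs to the hydroxyl and how much to the chlorine stays open, as the two compounds with a measured number each carry both groups. Also open, going by these compounds, is whether the number holds with a methoxy group in place of that hydroxyl or a bromine in place of that chlorine.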